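Ether ring replacement at the ketone of compound 1

The source may hold more compounds than are shown below. What is called first, only, known or untested is meant among the compounds shown, and "the series" means these compounds.

Compound 1 `CC(C)c1cc(OCC(=O)[C@H](CC(=O)O)NC(=O)[C@@H](NC(=O)COc2cccc3ccccc23)C(C)C)no1` has been run in a functional assay on Jurkat cells (Homo sapiens) for inhibition (a lower number here means a stronger inhibitor, a higher number a weaker inhibitor), and gives only a limit of the assay, > 200000 nM. That limit is what the limit of > 200000 nM in this assay, at which 1 of the 2 values shown sits, records; no number is known for compound 1 itself. Compound 2 `CC(C)[C@H](NC(=O)COc1cccc2ccccc12)C(=O)N[C@@H](CC(=O)O)C(=O)CSc1nnc(-c2ccccc2)o1` carries (5-phenyl-1,3,4-oxadiazol-2-yl)sulfanyl in place of (5-isopropyl-1,2-oxazol-3-yl)oxy on a saturated chain carbon bound to a carbonyl carbon, and in this assay compound 2 gives 150000 nM. Among the measured compounds shown here, the step of an at least 1.3-fold lower number from compound 1 to compound 2 (0.12 log units; that floor lies within the scatter) is the only measured change at this position; its floor lies within the scatter, so it shows no more than that both compounds sit at the weak end of what this assay can report.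

Compound 3 `CC(C)[C@H](NC(=O)COc1cccc2ccccc12)C(=O)N[C@@H](CC(=O)O)C(=O)COc1ccnc(C(F)(F)F)n1` differs from compound 1 as follows: 2-(trifluoromethyl)pyrimidin-4-yl in place of 5-isopropyl-1,2-oxazol-3-yl on an oxygen on a saturated carbon. The step from compound 1 to compound 2 bears on the same position and was small, so a step of similar size, not beyond the scatter, is expected here as well. In this assay compound 3 is expected to give 150000 nM, between 40000 nM and 600000 nM, which amounts to an expected at least 1.3-fold lower number from compound 1 to compound 3 (0.12 log units; that floor lies within the scatter).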

Compound 3, half-maximal inhibitory concentration: 37000 nM
For compound 3 the middle estimate is 4.1-fold (0.61 log units) above the measured one; the measured number lies below the stated range.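

Notes on the group on the saturated chain carbon bound to a carbonyl carbon: in this assay this position can now be seen to respond beyond the scatter, with an at least 5.4-fold lower number from compound 1 to compound 3 (0.73 log units; beyond the scatter) and a 4.1-fold lower number from compound 2 to compound 3 (0.61 log units; beyond the scatter), whereas the earlier step could not be told from the scatter. Compound 1 gives only a limit, so the first of these steps is a floor: the limit of > 200000 nM in this assay, at which 1 of the 3 values shown sits. That step keeps the oxygen link and changes only the ring group, so the ring group alone can shift the value, while the second step has numbers at both ends but changes the ring group and replaces the sulfur link with oxygen together, so it cannot apportion the shift between them.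

The compounds shown leave open whether the shift belongs to the trifluoromethyl or to the ring bearing it, which a methyl or a nitrile in its place on the pyrimidin-4-yl ring would address. They also leave open what the link contributes, which the sulfur-linked counterpart, (2-(trifluoromethyl)pyrimidin-4-yl)sulfanyl, would address when set against compound 3.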